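The source may report more compounds than this note shows. Statements on the series, on what has been measured and on what is new or still open speak of the compounds shown alone.

Measured compounds: compound 1 `CCC(c1ccccc1)c1nc(-c2ccc(Cl)cc2)c(CC(=O)O)s1` with > 100000 nM in an in vitro functional assay on HEK285-7 cells for antagonist activity at prostaglandin D2 receptor 2 (Homo sapiens), read by BRET and beta-arrestin recruitment; on this read-out lower numbers stand for stronger inhibition and higher numbers for weaker inhibition; compound 2 `NS(=O)(=O)c1ccc(-c2nc(C(c3ccc(F)cc3)c3ccc(F)cc3)sc2CC(=O)O)cc1` with > 100000 nM; compound 3 `COc1ccc(C(c2ccccc2)c2nc(-c3ccc(Cl)cc3)c(CC(=O)O)s2)cc1` with 76 nM.

The value of compound 1 is a limit of this assay, not a number. The value of compound 2 is also a limit. Compound 3 thus carries the only number shown, and the step of an at least 1300-fold lower number from compound 1 to compound 3 (3.11 log units; beyond the scatter) is the single measured step. Compound 4 `COc1ccc(C(c2ccccn2)c2nc(-c3ccc(Cl)cc3)c(CC(=O)O)s2)cc1` differs from compound 3 by pyridin-2-yl in place of phenyl on a saturated chain carbon bound to two aromatic carbons. Going by the values given here, no measured step concerns an aromatic ring being replaced by another aromatic ring at this position, so the large step from compound 1 to compound 3 gives no direct guide. A modest change is expected, a 2.0-fold higher number from compound 3 to compound 4 (0.30 log units; within the scatter). Compound 4 is therefore estimated at 150 nM, between 40 nM and 600 nM.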

Compound 4, half-maximal inhibitory concentration: 310 nM
Compound 4: middle estimate off by 2.1-fold (0.32 log units), on the low side, within the range that was stated.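

Replacing phenyl with pyridin-2-yl on a saturated chain carbon bound to two aromatic carbons gives a 4.1-fold higher number from compound 3 to compound 4 (0.61 log units; beyond the scatter) in this assay. This position therefore responds to an exchange of one aromatic ring for another, not only to the much larger exchange of ethyl for 4-methoxyphenyl, and compound 4 still gives a measured number rather than a limit. Nothing shown gives a cause for this step.

Going by these compounds, it remains open whether a methyl group or an amine on the pyridin-2-yl would change the number, and whether the same exchange in place of the 4-methoxyphenyl would give a step of similar size.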